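The compounds below may be only part of what the source reports. "The series", "measured", "known", "first", "only" and "open" are said of these compounds alone.

Measured so far in an assay on microsomes from intestinal mucosa for inhibition of acyl-CoA:cholesterol acyltransferase (Oryctolagus cuniculus); a lower number here means a stronger inhibitor, a higher number a weaker inhibitor:
compound 1 `CCCCCCCC/C=C\CCCCCCCCNC(=O)Nc1c(C)cccc1C`: 160 nM
compound 2 `CCCCCCCC/C=C\CCCCCCCCNC(=O)Nc1c(C)cc(C)cc1C`: 2900 nM
compound 3 `CCCCCCCC/C=C\CCCCCCCCNC(=O)Nc1cc(C)ccc1C`: 4500 nM

Compound 3 gives the highest of the three numbers in this assay. The nearest neighbour is reached by a 1.6-fold higher number from compound 2 to compound 3 (0.19 log units; within the scatter), a gap within the scatter; the furthest by a 28-fold higher number from compound 1 to compound 3 (1.45 log units; beyond the scatter), well beyond it. Compound 4 `CCCCCCCC/C=C\CCCCCCCCNC(=O)Nc1c(Cl)cccc1Cl` has not been measured. The change is 2,6-dichlorophenyl in place of 2,5-dimethylphenyl on an amide-type nitrogen. The step that bears on it most directly is a 28-fold higher number from compound 1 to compound 3 (1.45 log units; beyond the scatter), which runs through the same rearrangement of the two ring substituents in the opposite direction; compound 4 carries a 2,6-dichlorophenyl that matches the 2,6-dimethylphenyl of compound 1 in pattern. The step of an 18-fold higher number from compound 1 to compound 2 (1.26 log units; beyond the scatter) shows that adding a third methyl to that pattern also raises the number, so on this evidence the arrangement counts for more than the number of methyls. Going by the values given here, no measured step swaps methyl for chlorine, so that part of the change is uncovered. The expectation for compound 4 is therefore a large fall in the number, an 18-fold lower number from compound 3 to compound 4 (1.26 log units; beyond the scatter), landing near compound 1 but with a widened range. The estimated value of compound 4 in this assay is 250 nM, with a range from 60 nM to 1200 nM.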

Compound 4, half-maximal inhibitory concentration: 400 nM
Beside the measured number, compound 4's estimate is 1.6-fold (0.20 log units) below it; low and high end bracket the measured number.
By their numbers in this assay, from the lowest: compound 1; then compound 4; then compounds 2 and 3 (each within the scatter of the next).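

In this assay, 2,6-dichlorophenyl on the amide-type nitrogen gives a much lower number than 2,5-dimethylphenyl, with an 11-fold lower number from compound 3 to compound 4 (1.05 log units; beyond the scatter), and it also improves on 2,4,6-trimethylphenyl, with a 7.3-fold lower number from compound 2 to compound 4 (0.86 log units; beyond the scatter). The low numbers are therefore not confined to the methyl-bearing compound 1, although chlorine does not fully match methyl in the 2,6-substituted pair, which shows a 2.5-fold higher number from compound 1 to compound 4 (0.40 log units; beyond the scatter); compound 2 goes against any reading that 2,6-substitution alone is enough, as it also carries that pattern and has a high number. Nothing available here gives a reason for these steps.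

From the compounds shown here alone, it remains open whether the chlorine compounds would follow the methyl compounds, with 2,4,6-trichlorophenyl and 2,5-dichlorophenyl giving numbers as high as those of their methyl counterparts. Also open, going by these compounds, are whether fluorine, methoxy or isopropyl at the places held by the two chlorines would close the remaining gap to compound 1, and whether the ranking of these aryl groups would hold with a shorter saturated chain on the other urea nitrogen.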